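A chloro swap among closely matched cytotoxic compounds

The compounds below may be only part of what the source reports. "The series", "measured", "known", "first", "only" and "open" are said of these compounds alone.

In a functional assay on QGY-7703 cells (Homo sapiens) for cytotoxicity, read by MTT assay, with a stated time of 24 h (a higher number here means a weaker inhibitor, a lower number a stronger inhibitor), compound 1 `CN1C/C(=C\c2ccncc2)C(=O)/C(=C/c2ccccc2C(F)(F)F)C1` gives 4500 nM and compound 2 `O=C1/C(=C/c2cccnc2)CN(S(=O)(=O)c2ccc(Cl)cc2)C/C1=C\c1ccccc1C(F)(F)F` gives 3440 nM while compound 3 `O=C1/C(=C/c2ccncc2)CN(S(=O)(=O)c2ccc(C(F)(F)F)cc2)C/C1=C\c1ccccc1C(F)(F)F` gives 4680 nM and so stands within the scatter of both. Compound 4 `O=C1/C(=C/c2ccncc2)CN(S(=O)(=O)c2ccc(Cl)cc2)C/C1=C\c1ccccc1C(F)(F)F` differs from compound 3 by chloro in place of trifluoromethyl on an aromatic carbon which turns 4-(trifluoromethyl)phenyl into 4-chlorophenyl. Among the measured compounds shown here, no measured pair isolates this change, and the three measured values lie within the scatter of one another, so no step beyond the scatter is expected in this assay here. The expected step is small, a 1.2-fold lower number from compound 3 to compound 4 (0.08 log units; within the scatter) and within the scatter. For compound 4 the estimate is 3900 nM with an expected range of 2100 nM to 7200 nM in this measurement.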

Compound 4, half-maximal inhibitory concentration: 12700 nM
The estimate for compound 4 lay 3.3-fold (0.51 log units) below the measured number; the whole stated range lies below it.
By their numbers in this assay, from the lowest: compounds 2, 1 and 3 (each within the scatter of the next); then compound 4.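

In this assay, among the compounds shown here, the group on this aromatic carbon matters, since chloro in place of trifluoromethyl gives a 2.7-fold higher number from compound 3 to compound 4 (0.43 log units; beyond the scatter) and so breaks the closeness of the earlier compounds. The chloro compound also stands apart from its other neighbours, with pyridin-4-yl in place of pyridin-3-yl giving a 3.7-fold higher number from compound 2 to compound 4 (0.57 log units; beyond the scatter) and (4-chlorophenyl)sulfonyl in place of methyl giving a 2.8-fold higher number from compound 1 to compound 4 (0.45 log units; beyond the scatter) in this series. No measurement shown here explains these steps. From the compounds shown here alone, whether fluoro or methoxy at this place would track chloro or trifluoromethyl remains open, as does whether the trifluoromethyl-to-chloro step holds with pyridin-3-yl.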